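The source may report more compounds than this note shows. Statements on the series, on what has been measured and on what is new or still open speak of the compounds shown alone.

Compound 3 `O=C(NS(=O)(=O)c1ccccc1)c1ccc(Nc2nc(NC3(c4ccc(Cl)cc4)CC3)nc(OCC(F)(F)F)n2)cc1` is one of three close analogues sharing a common core. In an ADME assay on microsomes from liver (Homo sapiens) for metabolic stability, with a stated time of 10 min (a higher number here means that more of the compound is left, a lower number that less of the compound is left), compound 3 gives 100%. Compound 1 `O=C(NS(=O)(=O)c1ccc(F)cc1)c1ccc(Nc2nc(NC3(c4ccc(Cl)cc4)CC3)nc(OCC(F)(F)F)n2)cc1` gives 100% in this assay, and compound 2 `CC(C)OC(=O)NCCS(=O)(=O)NC(=O)c1ccc(Nc2nc(NC3(c4ccc(Cl)cc4)CC3)nc(OCC(F)(F)F)n2)cc1` gives 100%, so compound 3 stands level with both of them at the digits shown. The step from compound 1 to compound 3 is no change at the digits printed from compound 1 to compound 3 (within the scatter), and the step from compound 2 to compound 3 is no change at the digits printed from compound 2 to compound 3 (within the scatter).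

Compound 4 `CC(C)NC(=O)NCCS(=O)(=O)NC(=O)c1ccc(Nc2nc(NC3(c4ccc(Cl)cc4)CC3)nc(OCC(F)(F)F)n2)cc1` differs from compound 3 in one place: 2-((isopropylcarbamoyl)amino)ethyl in place of phenyl on a sulfonyl sulfur. The step that bears most directly on this change is the one on the sulfonyl sulfur, from compound 1 to compound 2, which reads no change at the digits printed from compound 1 to compound 2 (within the scatter), and the reverse exchange from compound 2 to compound 3 likewise gave no change at the digits printed from compound 2 to compound 3 (within the scatter). Exchange of the group on the sulfonyl sulfur has so far left this assay unmoved. Compound 4 is therefore expected to show no step beyond the scatter, an estimated no change at the digits printed from compound 3 to compound 4 (within the scatter). Compound 4 is estimated at 100%, within a range from 85% to 100%.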

Compound 4, percent of the compound remaining: 100%
Compound 4: middle estimate and measured number agree at the digits printed, and the stated range covers the measured number.
By their numbers in this assay, from the lowest: compounds 1, 2, 3 and 4 (each within the scatter of the next).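

In this assay the sulfonyl sulfur, whose other neighbour is the amide-type nitrogen, carries 2-((isopropylcarbamoyl)amino)ethyl with no change at the digits printed from compound 3 to compound 4 (within the scatter) in place of phenyl and with no change at the digits printed from compound 1 to compound 4 (within the scatter) in place of 4-fluorophenyl. Within the chain itself, isopropylamino in place of isopropoxy on a carbonyl carbon gives no change at the digits printed from compound 2 to compound 4 (within the scatter) as a further exchange that leaves this assay level. No measurement is shown that could account for this flat reading.

All the compounds shown sit at one printed value, so these results do not show which change on the sulfonyl sulfur, if any, would lower the read-out. On these data alone, it remains open whether a longer chain, or a terminal amine or carboxylic acid in place of the isopropylamino group, would stay level as well.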